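Cytotoxicity on Akata cells: isopropylamino to butylamino

A few compounds are considered here, and "the series" means these few. Any claim that something is new, unique, unknown or untested is made for them only; others in the source may bear on it.

Three analogues of the shared core have been tested in an ADME assay on Akata cells (Homo sapiens) for cytotoxicity, with a stated time of 7 days; a lower number here means that less compound is tolerated, a higher number that more compound is tolerated. Compound 1 `CCOc1nc(N)nc2c1ncn2/C=C1/CC1(CO)CO` and compound 2 `Nc1nc(OCc2ccccc2)c2ncn(/C=C3/CC3(CO)CO)c2n1` both reach only the limit of this assay. In this assay compound 1 gives > 20000 nM, which is a limit and not a number. In this assay compound 2 gives > 20000 nM, again a limit. Compound 3 `CC(C)Nc1nc(N)nc2c1ncn2/C=C1/CC1(CO)CO` likewise sits at a limit. In this assay compound 3 gives > 24000 nM, a limit and not a number. Among the compounds with values here, because of the limit of > 20000 nM in this assay, at which 2 of the 3 values shown sit, and the limit of > 24000 nM in this assay, at which 1 of the 3 values shown sits, none of the measured steps can be read: a step that the two limits leave unreadable from compound 1 to compound 2, a step that the two limits leave unreadable from compound 1 to compound 3 and a step that the two limits leave unreadable from compound 2 to compound 3. Compound 3 therefore stands at the top of what this assay reports, alongside the other two.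

Compound 4 `CCCCNc1nc(N)nc2c1ncn2/C=C1/CC1(CO)CO` differs from compound 3 by butyl in place of isopropyl on a nitrogen on an aromatic ring. No measured step bears on this change, since every shown step is unreadable. The expectation is that the change from isopropylamino to butylamino leaves compound 4 tolerated at a similar level, so the step that the limit leaves unreadable from compound 3 to compound 4 is expected to stay within the scatter. Compound 4 is estimated to give 30000 nM in this assay, in the range 12000 nM to 100000 nM, most likely reported only as a limit.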

Compound 4, half-maximal cytotoxic concentration: > 24000 nM
Compound 4: no number, only a limit; the forecaster's own chance of this, stated with the estimate: 80%; the middle value does not contradict the limit.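

In this assay compound 4 gives > 24000 nM, a limit and not a number. Its steps from compound 1, compound 2 and compound 3 therefore cannot be read. The compounds shown leave open whether any of these groups on the aromatic carbon changes the tolerated concentration in this assay at all.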